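A Sulfonyloxy Group Added to the Benzamide Ring

The compounds below may be only part of what the source reports. "The series", "measured", "known", "first", "only" and "open" are said of these compounds alone.

Three amides have so far been measured in an assay on membranes from brain for binding affinity to metabotropic glutamate receptor 5 (Rattus norvegicus); on this read-out higher numbers stand for weaker inhibition and lower numbers for stronger inhibition. Compound 1 `Cc1csc(NC(=O)c2cccc(Cl)c2)n1` gives 5490 nM. Compound 2 `Cc1cccc(NC(=O)c2ccccc2)n1` gives 35000 nM, and compound 3 `Cc1cccc(NC(=O)c2cccc3ccccc23)n1` gives 62800 nM. Among these three numbers compound 2 stands second highest. Its nearest neighbour is compound 3, whose number is slightly higher but within the usual scatter, so the two cannot be told apart. Its furthest neighbour is compound 1, whose number is clearly lower, beyond the scatter; compound 1, however, carries a different core, so this gap cannot be pinned to any single change.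

Compound 4 `Cc1cccc(NC(=O)c2cccc(OS(C)(=O)=O)c2)n1` keeps the core and the amide of compound 2 and differs in one place: (methylsulfonyl)oxy in place of hydrogen on an aromatic carbon, placed meta to a large group. Within the data shown here, no measured pair shows this particular change, so its effect is unknown from the data at hand. A step from compound 2 to compound 4 of a 1.8-fold lower number from compound 2 to compound 4 (0.24 log units; within the scatter) is expected, modest and leaning toward a lower number, yet likely not far outside the scatter. Compound 4 is therefore estimated at 20000 nM, with a plausible range from 6000 nM to 70000 nM.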

Compound 4, half-maximal inhibitory concentration: 83600 nM
Compound 4: middle estimate off by 4.2-fold (0.62 log units), on the low side; the whole stated range lies below it.
By their numbers in this assay, from the lowest: compound 1; then compounds 2, 3 and 4 (each within the scatter of the next, the first and the last beyond it).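

Among these compounds, the first single-place step comes from putting (methylsulfonyl)oxy in place of hydrogen on an aromatic carbon, meta to a large group: in this assay it gives a 2.4-fold higher number from compound 2 to compound 4 (0.38 log units; beyond the scatter). A higher number here means weaker inhibition, so this change at this position does not strengthen inhibition, though the step is modest and compound 4 still gives a measurable 83600 nM. Nothing at hand explains why the number moves in this direction.

Among the compounds shown here, with only one group tested at this position, the data cannot separate an effect of (methylsulfonyl)oxy itself from a more general effect of placing any group there, and a methoxy group, an amine or a carboxylic acid in the same place could give a different answer. As far as these compounds go, it also remains open how (methylsulfonyl)oxy would behave elsewhere on the same aromatic ring, or whether the same change would shift the number in the same direction on the core of compound 1.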